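The compounds below may be only part of what the source reports. "The series", "measured", "known", "first", "only" and "open" are said of these compounds alone.

Measured so far in a functional assay on MCF7 cells (Homo sapiens) for antiproliferative activity, read by MTT assay, with a stated time of 48 h; on this read-out higher numbers stand for weaker inhibition and lower numbers for stronger inhibition:
- compound 1 `CCn1c(C(=O)NCCN(C)C)ccc1C(CC)(CC)c1ccc(OCCC(O)(CC)CC)c(C)c1`: 430 nM
- compound 2 `CCn1c(C(=O)NCC#N)ccc1C(CC)(CC)c1ccc(OCCC(O)(CC)CC)c(C)c1`: > 50000 nM (a limit)
- compound 3 `C=CCN(C)C(=O)c1ccc(C(CC)(CC)c2ccc(OCCC(O)(CC)CC)c(C)c2)n1CC`: > 50000 nM (a limit)

Compound 3 gives no number, only a limit, > 50000 nM. It stands at the limit of > 50000 nM in this assay, at which 2 of the 3 values shown sit. Only compound 1 gives a number, 430 nM.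

Next is compound 4 `C#CC(C)OC(=O)c1ccc(C(CC)(CC)c2ccc(OCCC(O)(CC)CC)c(C)c2)n1CC`. The change is (1-methylprop-2-yn-1-yl)oxy in place of allyl(methyl)amino on a carbonyl carbon.

Among the measured compounds shown here, no measured step covers this replacement directly. The nearest evidence comes from two large steps that start at compound 1: an at least 110-fold higher number from compound 1 to compound 2 (2.06 log units; beyond the scatter) and an at least 110-fold higher number from compound 1 to compound 3 (2.06 log units; beyond the scatter). In both, the (dimethylamino)methyl end of the chain on the carbonyl side is lost, and with it the measurable number. The remaining step, a step that the two limits leave unreadable from compound 2 to compound 3, gives no size. Among the three compounds, only the one carrying (2-(dimethylamino)ethyl)amino on the carbonyl carbon gives a number, and compound 4 lacks that group too. No recovery is therefore expected, and no step beyond the scatter in either direction, with a further limit the likeliest report from this assay. The estimated step reads a number no higher from compound 3 to compound 4 (the limit leaves the size open). The estimate for compound 4 is 50000 nM, expected within 15000 nM to 150000 nM.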

Compound 4, half-maximal inhibitory concentration: > 50000 nM
Compound 4 gave a limit, no number (the forecaster's own chance of this, stated with the estimate: 80%); the middle value lies on the limit itself.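

In this assay, replacing (2-(dimethylamino)ethyl)amino on the carbonyl carbon with (1-methylprop-2-yn-1-yl)oxy gives an at least 110-fold higher number from compound 1 to compound 4 (2.06 log units; beyond the scatter), which extends the loss of a measurable number from the amide-type groups of compound 2 and compound 3 to a group attached through oxygen, with a triple bond and a hydrogen-bond acceptor. The steps among compound 2, compound 3 and compound 4 cannot be read, as each pair consists of two limits, so the exchange of allyl(methyl)amino for (1-methylprop-2-yn-1-yl)oxy cannot be ranked. With this further limit, the position now stands as follows: the limit of > 50000 nM in this assay, at which 3 of the 4 values shown sit.

Among the compounds shown here, compound 1 remains the only compound with a number, 430 nM, so it remains open whether the dimethylamino end is specifically needed or whether another amine, such as a morpholine or diethylamino end, would also give a number. Also open, on these data alone, are the effects of a longer chain between the amide nitrogen and the dimethylamino group, and of a carboxylic acid on the same chain.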